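This account rests on a few compounds, and the source may have more. Where it says the series, first, only, none or still open, it means among the compounds named here.

Compound 1 `CC(C)N1CCN(c2nc(Nc3ccc(C#N)c(C(F)(F)F)c3)nc(Oc3ccnc4ccccc34)n2)CC1` reports only a limit of the assay in a functional assay on DU-145 cells (Homo sapiens) for cytotoxicity, read by sulforhodamine B assay, with a stated time of 48 h (a lower number here means a stronger inhibitor of growth, a higher number a weaker inhibitor of growth), namely > 100000 nM. Compound 2 `N#Cc1ccc(Nc2nc(Oc3ccnc4ccccc34)nc(N3CCN(c4ncccn4)CC3)n2)cc1C(F)(F)F` gives 85200 nM in this assay. Compound 3 `N#Cc1ccc(Nc2nc(Oc3ccnc4ccccc34)nc(N3CCN(c4ccccc4F)CC3)n2)cc1C(F)(F)F` likewise reports only a limit in this assay, > 100000 nM.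

Compound 3 thus sits at the ceiling of the measurements, shared by two of the three values (the limit of > 100000 nM in this assay, at which 2 of the 3 values shown sit). Compound 4 `N#Cc1ccc(Nc2nc(Oc3ccnc4ccccc34)nc(N3CCN(c4cccc(C(F)(F)F)c4)CC3)n2)cc1C(F)(F)F` differs from it by 3-(trifluoromethyl)phenyl in place of 2-fluorophenyl on an amine nitrogen in a ring. Among the compounds with values here, the measured steps that bear on this are a step that the two limits leave unreadable from compound 1 to compound 3 and an at least 1.1-fold higher number from compound 2 to compound 3 (0.06 log units; that floor lies within the scatter); neither exchanges one aryl group for another, and no step among the three compounds rises beyond the scatter or is even readable. No movement beyond the scatter is therefore expected in this assay. Compound 4 is expected to give 100000 nM, within 40000 nM to 100000 nM. The expected step of a number no higher from compound 3 to compound 4 (the limit leaves the size open) stays within the scatter.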

Compound 4, concentration for 50% growth inhibition: 38700 nM
Beside the measured number, compound 4's estimate is 2.6-fold (0.41 log units) above it; measured number outside the range, below it.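

Placing 3-(trifluoromethyl)phenyl instead of 2-fluorophenyl on the amine nitrogen gives an at least 2.5-fold lower number from compound 3 to compound 4 (0.41 log units; beyond the scatter) in this assay and is the first step in this series to reach beyond the scatter. Against pyrimidin-2-yl, the same group gives a 2.2-fold lower number from compound 2 to compound 4 (0.34 log units; beyond the scatter) and against isopropyl an at least 2.5-fold lower number from compound 1 to compound 4 (0.41 log units; beyond the scatter) on that nitrogen. The sizes involving compound 1 and compound 3 are only floors, as both compounds report a limit of the assay: the limit of > 100000 nM in this assay, at which 2 of the 4 values shown sit.

Going by these compounds, whether the drop follows from the trifluoromethyl group itself or from where it sits on the phenyl ring remains open. On these data alone, how an amine or a carboxylic acid on that phenyl ring would read also remains open.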